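Isopropyl to Isobutyl Swap Carried onto a Second Core

The source may hold more compounds than are shown below. What is called first, only, known or untested is meant among the compounds shown, and "the series" means these compounds.

Compound 1 `C=CCONC(=O)Cn1cc(C(=O)N[C@@H](C)C(=O)N[C@H](C(=O)O)C(C)C)c2ccccc21` was run in a functional assay on MRC5 cells (Homo sapiens) for inhibition, read by microscopy and resazurin assay, with a stated time of 72 h; a higher number here means a weaker inhibitor, a lower number a stronger inhibitor; compound 1 gives > 128000 nM, which is a limit of the assay. Compound 2 `C=CCONC(=O)Cn1cc(C(=O)N[C@@H](C)C(=O)N[C@@H](CC(C)C)C(=O)O)c2ccccc21` carries isobutyl in place of isopropyl on a saturated chain carbon bound to an amide-type nitrogen and a carbonyl carbon. In this assay compound 2 gives > 128000 nM, again a limit. The step that the two limits leave unreadable from compound 1 to compound 2 cannot be sized, since both values sit at the limit of > 128000 nM in this assay, at which 3 of the 3 values shown sit.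

Compound 3 `C=CCONC(=O)Cn1ccc(C(=O)N[C@@H](C)C(=O)N[C@H](C(=O)O)C(C)C)c1` rests on a different core; the difference between the two cores is not broken down here. In this assay compound 3 gives > 128000 nM, a limit as well.

Compound 4 `C=CCONC(=O)Cn1ccc(C(=O)N[C@@H](C)C(=O)N[C@@H](CC(C)C)C(=O)O)c1` differs from compound 3 by isobutyl in place of isopropyl on a saturated chain carbon bound to an amide-type nitrogen and a carbonyl carbon, the same change as from compound 1 to compound 2. The step that the limit leaves unreadable from compound 3 to compound 4 is expected to be negligible, resting on the two measured partners of this change both sitting at the limit of > 128000 nM in this assay, at which 3 of the 3 values shown sit. Compound 4 is therefore estimated at 200000 nM in this assay, most probably reported as a further limit rather than a number.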

Compound 4, half-maximal inhibitory concentration: > 128000 nM
Compound 4 was reported as a limit; the forecaster's own chance of this, stated with the estimate: 90%; the middle value is on the limit's open side.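

No step can be read for compound 3 and compound 4 in this assay, as both values are limits: the limit of > 128000 nM in this assay, at which 4 of the 4 values shown sit.

On these data alone, whether isobutyl in place of isopropyl shifts inhibition on either core stays open.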